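A few compounds are considered here, and "the series" means these few. Any claim that something is new, unique, unknown or untested is made for them only; others in the source may bear on it.

Of the compounds shown here, two from this series have been tested in a functional assay on CHO cells for agonist activity at Free fatty acid receptor 2 (Homo sapiens), read by cAMP accumulation; a lower number here means a smaller maximal response, a higher number a larger maximal response. Compound 1, `CC(C)[C@H](C(=O)Nc1nc(C(F)(F)F)cs1)c1ccc(Cl)cc1`, carries an isopropyl group on the saturated chain carbon and a trifluoromethyl group on its core; in this assay compound 1 gives 123%. Compound 2, `CC(C)C[C@H](C(=O)Nc1nccs1)c1ccc(Cl)cc1`, carries an isobutyl group and a core without the trifluoromethyl group; in this assay compound 2 gives 68%. Of the two values, compound 2 holds the lower one, and the gap to compound 1 is wider than the usual scatter. The two compounds differ in more than one place, so no single change can be tied to that gap.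

Compound 3, `C=CC[C@H](C(=O)Nc1nccs1)c1ccc(Cl)cc1`, keeps the core of compound 2 and changes only the chain: vinyl in place of isopropyl on a saturated chain carbon, two bonds along the chain from an aromatic carbon and a carbonyl carbon. Among the compounds with values here, nothing among the measured compounds isolates this kind of change, so the direction of its effect is open. The step of a number 2 percentage points higher from compound 2 to compound 3 (within the scatter) is expected to be small and to stay within the usual scatter. On this basis compound 3 is expected to reach about 70%, with a likely range from 40% to 100%.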

Compound 3, largest response reached (reported as efficacy), in percent of the reference or control that the assay uses: 88%
Estimate against measurement, compound 3: 18 percentage points below, within the range that was stated.
By their numbers in this assay, from the lowest: compound 2; then compound 3; then compound 1.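

In this assay, vinyl in place of isopropyl on a saturated chain carbon, two bonds along the chain from an aromatic carbon and a carbonyl carbon, gives a number 20 percentage points higher from compound 2 to compound 3 (beyond the scatter). Within the data shown here, this is the first comparison that can be read for a single change: the core stays the same and only the chain differs, so the shift in maximal response can be tied to this position, which the two earlier compounds, differing in more than one place, could not show. What lies behind the larger response remains unexplained, as no supporting measurement bears on this step.

The change from isobutyl to allyl alters both the carbon count and the presence of a double bond, so the compounds shown do not separate these two differences; a saturated propyl chain at the same carbon would bear directly on that question. Also open, as far as these compounds go, are whether the same step would hold on the trifluoromethyl core of compound 1 and how a chain ending in an amine or a carboxylic acid would fare.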